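The source may report more compounds than this note shows. Statements on the series, on what has been measured and on what is new or still open speak of the compounds shown alone.

Measured compounds in a functional assay on EKVX cells (Homo sapiens) for inhibition, read by sulforhodamine B assay, with a stated time of 48 h, tested at 10 uM; a lower number here means less inhibition, a higher number more inhibition at the concentration tested (going by the name of the read-out):
compound 1 `COc1ccc(-c2cn3ccnc3c(-c3ccc4ncn(C5CCCCC5)c4c3)n2)cc1` gives 56.7%
compound 2 `c1ccc2c(-c3cn4ccnc4c(-c4ccc5ncn(C6CCCCC6)c5c4)n3)cccc2c1` gives 13.3%
compound 3 `Fc1ccc(-c2cn3ccnc3c(-c3ccc4ncn(C5CCCCC5)c4c3)n2)cc1` gives 10.5%

Compound 3 stands lowest of the three numbers in this assay. Its nearest neighbour is compound 2, and the step of a number 2.8 percentage points lower from compound 2 to compound 3 (within the scatter) lies within the scatter, so the two cannot be ordered. The furthest is compound 1, reached by a number 46.2 percentage points lower from compound 1 to compound 3 (beyond the scatter), which is a large step beyond the scatter.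

The next compound is compound 4 `COc1ccccc1-c1cn2ccnc2c(-c2ccc3ncn(C4CCCCC4)c3c2)n1`. Against compound 3 the change is 2-methoxyphenyl in place of 4-fluorophenyl on an aromatic carbon.

Within the data shown here, two measured steps bear on it. The step of a number 46.2 percentage points lower from compound 1 to compound 3 (beyond the scatter) shows that replacing methoxy with fluoro on the aromatic carbon cost most of the inhibition, while a number 43.4 percentage points lower from compound 1 to compound 2 (beyond the scatter) shows that naphthalen-1-yl in place of 4-methoxyphenyl cost about as much. Among the measured compounds shown here, compound 4 returns a methoxy group, but as 2-methoxyphenyl rather than the 4-methoxyphenyl of compound 1, and no measured pair shows that exact change. The expectation is therefore a rise in this assay, but a smaller one than the full distance back to compound 1, and with wide uncertainty.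

For compound 4 the expected step is a number 19.5 percentage points higher from compound 3 to compound 4 (beyond the scatter). Compound 4 is estimated at 30%, with a range from 8% to 58%.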

Compound 4, a percentage reported as inhibition, at one concentration (the size of the read-out at that concentration, not a potency): 13.4%
The estimate for compound 4 lay 16.6 percentage points above the measured number; the range from low to high includes it.
By their numbers in this assay, from the lowest: compounds 3, 2 and 4 (each within the scatter of the next); then compound 1.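

In this assay, the exchange of 4-methoxyphenyl for 2-methoxyphenyl on this aromatic carbon, a number 43.3 percentage points lower from compound 1 to compound 4 (beyond the scatter), shows that the presence of a methoxy group on the phenyl ring does not by itself keep the inhibition: how the group is placed on that ring decides the result. With a number 2.9 percentage points higher from compound 3 to compound 4 (within the scatter) and a number 0.1 percentage points higher from compound 2 to compound 4 (within the scatter), 2-methoxyphenyl cannot be separated from 4-fluorophenyl or naphthalen-1-yl, so among the four groups shown at this position only the 4-methoxyphenyl of compound 1 stands apart. The data at hand offer no explanation for this dependence on the placement of the methoxy group.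

The compounds shown leave open whether the higher number of compound 1 is specific to methoxy or would also appear with a hydroxyl, an ethoxy group or an amine in the place that methoxy holds in 4-methoxyphenyl. They also leave open whether the same order would hold at other concentrations, since a reading at a single concentration gives no potency.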